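The compounds below may be only part of what the source reports. "The series", "measured", "known", "first", "only" and "open" are said of these compounds alone.

Notes on the series. Compound 1 `COc1cc(OC)c2sc(-c3ccc(N/C=C\C(=O)c4ccc(OC)c([N+](=O)[O-])c4)c(C)c3)nc2c1` and compound 2 `COc1cc(OC)c2sc(-c3ccc(N/C=C\C(=O)c4ccc(OC)c([N+](=O)[O-])c4)cc3)nc2c1` share one core; in a functional assay on A549 cells (Homo sapiens) for antiproliferative activity, read by sulforhodamine B assay, with a stated time of 48 h (a lower number here means a stronger inhibitor, a higher number a weaker inhibitor), compound 1 gives 12100 nM and compound 2 gives 5800 nM. The change hydrogen in place of methyl on an aromatic carbon gave a 2.1-fold lower number from compound 1 to compound 2 (0.32 log units; beyond the scatter). Compound 3 `COc1ccc2nc(-c3ccc(N/C=C\C(=O)c4cc(OC)c(OC)c(OC)c4Br)c(C)c3)sc2c1` rests on a second core; the difference between the two cores is not broken down here. In this assay compound 3 gives 6400 nM, within the scatter of compound 2. Compound 4 `COc1ccc2nc(-c3ccc(N/C=C\C(=O)c4cc(OC)c(OC)c(OC)c4Br)cc3)sc2c1` differs from compound 3 by hydrogen in place of methyl on an aromatic carbon, the same kind of change as the earlier one; the two places read alike except that the first is meta to a large group and the second meta to a 6-methoxy-1,3-benzothiazol-2-yl group. Among the compounds with values here, for compound 4 a step of about a 2.0-fold lower number from compound 3 to compound 4 (0.30 log units; within the scatter) is expected, resting on the one earlier step of a 2.1-fold lower number from compound 1 to compound 2 (0.32 log units; beyond the scatter), which stands alone and on a different core, so the range is kept wide. Compound 4 is estimated at 3200 nM in this assay, between 1500 nM and 7000 nM.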

Compound 4, half-maximal inhibitory concentration: 6000 nM
For compound 4 the middle estimate is 1.9-fold (0.27 log units) below the measured one; low and high end bracket the measured number.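

In this assay hydrogen in place of methyl on the second core gives a 1.1-fold lower number from compound 3 to compound 4 (0.03 log units; within the scatter) and so no readable change. Set beside the step on the first core, this step does not differ from it by more than repeated measurement allows: the same change on two cores in this assay, a 2.1-fold lower number (0.32 log units; beyond the scatter) from compound 1 to compound 2 and a 1.1-fold lower number (0.03 log units; within the scatter) from compound 3 to compound 4, 2.0-fold (0.29 log units) apart, within the scatter of two such steps. The two pairs give no sign that the core alters this change, but with a single pair on each core they do not establish that its size is the same on both.

Only methyl and hydrogen stand at this aromatic carbon, leaving open what an ethyl, a chlorine or an amine there would do. Also open is which of the differences between the two cores matters, as no pair shown separates them.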